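The compounds below may be only part of what the source reports. "The series", "measured", "known", "first", "only" and "open" are said of these compounds alone.

Compound 3, `CN1CCC[C@@H]1Cn1c(N)nc2ccc(C(=O)c3ccccc3)cc21`, is known in an ADME assay on HL-60 cells (Homo sapiens) for cytotoxicity, read by resazurin assay, with a stated time of 72 h (a higher number here means that more compound is needed for the effect, a lower number that less compound is needed), only as a limit: compound 3 gives > 30000 nM. Compound 1, `Nc1nc2ccc(C(=O)c3ccccc3)cc2n1C[C@H]1CCCN1`, likewise reaches only the limit > 30000 nM in this assay. Compound 2, `Nc1nc2ccc(C(=O)c3ccccc3)cc2n1C[C@@H]1CCCN1`, also stops at the limit > 30000 nM. The steps a step that the two limits leave unreadable from compound 1 to compound 2, a step that the two limits leave unreadable from compound 1 to compound 3 and a step that the two limits leave unreadable from compound 2 to compound 3 therefore carry no readable size because of the limit of > 30000 nM in this assay, at which 3 of the 3 values shown sit. Compound 4, `CC(C)(C)Cn1c(N)nc2ccc(C(=O)c3ccccc3)cc21`, differs from compound 3 in one place: tert-butyl in place of 1-methylpyrrolidin-2-yl on a saturated chain carbon bound to an aromatic nitrogen. Within the data shown here, no measured step bears on this change, and the values shown give no direction beyond the scatter. Compound 4 is therefore expected to show a step that the limit leaves unreadable from compound 3 to compound 4, most likely again only a limit, with an estimate of 40000 nM and a range from 10000 nM to 150000 nM.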

Compound 4, half-maximal effective concentration: > 30000 nM
Compound 4: no number, only a limit (the forecaster's own chance of this, stated with the estimate: 80%); the middle value is on the limit's open side.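

In this assay, among these compounds, compound 4 also gives only a limit, so no step from compound 1, compound 2 or compound 3 to compound 4 can be read: the limit of > 30000 nM in this assay, at which 4 of the 4 values shown sit. The compounds shown leave open whether tert-butyl, pyrrolidin-2-yl and 1-methylpyrrolidin-2-yl differ at all in their effect.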